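The source may report more compounds than this note shows. Statements on the series, on what has been measured and on what is new or still open speak of the compounds shown alone.

In a functional assay on OVCAR-3 cells (Homo sapiens) for inhibition, read by sulforhodamine B assay, with a stated time of 48 h, tested at 10 uM (a higher number here means more inhibition at the concentration tested (going by the name of the read-out), a lower number less inhibition), three compounds have been measured:

compound 1 `O=Cc1ccc(-c2cn3ccnc3c(-c3ccc4ncn(C5CCCCC5)c4c3)n2)cc1` gives 23.7%
compound 2 `c1ccc2c(-c3cn4ccnc4c(-c4ccc5ncn(C6CCCCC6)c5c4)n3)cccc2c1` gives 2.38%
compound 3 `O=Cc1ccc(-c2cn3ccnc3c(-c3ccc4ncn(Cc5ccccc5)c4c3)n2)cc1` gives 23.7%

Compound 4 `c1ccc(Cn2cnc3ccc(-c4nc(-c5cccc6ccccc56)cn5ccnc45)cc32)cc1` has not yet been measured in this assay. It differs from compound 3 by naphthalen-1-yl in place of 4-formylphenyl on an aromatic carbon. The same change, (naphthalen-1-yl in place of 4-formylphenyl on an aromatic carbon), links compound 1 to compound 2, where the step was a number 21.3 percentage points lower from compound 1 to compound 2 (beyond the scatter). The two starting points differ from each other in their core by benzyl in place of cyclohexyl on an aromatic nitrogen, a change that made no change at the digits printed from compound 1 to compound 3 (within the scatter); the surroundings of the exchanged group read the same in both pairs. Going by the values given here, with only one earlier example of this change, the expectation for compound 4 rests on it alone: the step from compound 3 is estimated as a number 20.7 percentage points lower from compound 3 to compound 4 (beyond the scatter), because of a number 21.3 percentage points lower from compound 1 to compound 2 (beyond the scatter) seen between compound 1 and compound 2. Compound 4 is therefore expected to give about 3% in this assay, likely between -8% and 14%.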

Compound 4, a percentage reported as inhibition, at one concentration (the size of the read-out at that concentration, not a potency): 1.44%
For compound 4 the middle estimate is 1.6 percentage points above the measured one; low and high end bracket the measured number.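

In this assay, putting naphthalen-1-yl in place of 4-formylphenyl gave a number 22.3 percentage points lower from compound 3 to compound 4 (beyond the scatter), which matches the step seen on the cyclohexyl core: the same change on two cores in this assay, a number 21.3 percentage points lower (beyond the scatter) from compound 1 to compound 2 and a number 22.3 percentage points lower (beyond the scatter) from compound 3 to compound 4, 0.9 percentage points apart, within the scatter of two such steps. With naphthalen-1-yl in place, benzyl instead of cyclohexyl on the aromatic nitrogen gave a number 0.9 percentage points lower from compound 2 to compound 4 (within the scatter), so this exchange also carried over: the same change on two cores in this assay, no change at the digits printed (within the scatter) from compound 1 to compound 3 and a number 0.9 percentage points lower (within the scatter) from compound 2 to compound 4, 0.9 percentage points apart, within the scatter of two such steps. Going by these compounds alone, the two changes therefore acted independently in these four compounds, but this rests on only two closely related cores at a single concentration, so it shows neither a rule for the whole series nor a potency.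

As far as these compounds go, it remains open whether the drop follows the loss of the formyl group or the gain of the second ring, which a plain phenyl group in that place could help separate. Also open, from the compounds shown here alone, is how an amine or a carboxylic acid on that phenyl ring would compare with compound 3.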